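Series notes: chloro removal on the core of compound 2

A few compounds are considered here, and "the series" means these few. Any claim that something is new, unique, unknown or untested is made for them only; others in the source may bear on it.

Measured so far:
compound 1 `O=c1c(Cl)c(CSC(=S)N2CCCCC2)oc2ccccc12`: 770 nM in a functional assay on MDA-MB-435S cells (Homo sapiens) for antiproliferative activity, read by MTT assay, with a stated time of 72 h; a higher number here means a weaker inhibitor, a lower number a stronger inhibitor
compound 2 `CC(C)N(C(=S)SCc1oc2ccccc2c(=O)c1Cl)C(C)C`: 23600 nM in this assay

Within the data shown here, compound 2 carries the highest number of the two measured compounds; the only measured step, a 31-fold higher number from compound 1 to compound 2 (1.49 log units; beyond the scatter), concerns the amine part and not the ring substituent. Compound 3 `CC(C)N(C(=S)SCc1cc(=O)c2ccccc2o1)C(C)C` differs from compound 2 by hydrogen in place of chloro on an aromatic carbon. Among the measured compounds shown here, no measured step touches this position, so no direction can be drawn from the data; the step is expected to stay modest, a 1.5-fold higher number from compound 2 to compound 3 (0.17 log units; within the scatter), with wide uncertainty. Compound 3 is estimated at 35000 nM, range 8000 nM to 150000 nM.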

Compound 3, half-maximal inhibitory concentration: > 40000 nM
Compound 3: no number, only a limit; the forecaster's own chance of this, stated with the estimate: 15%; middle value at least 1.1-fold (0.05 log units) away from the limit.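

In this assay, compound 3 gives only a limit and not a number: the limit of > 40000 nM in this assay, at which 1 of the 3 values shown sits. Hydrogen in place of chloro on this aromatic carbon, two atoms from the ring oxygen, gives an at least 1.6-fold higher number from compound 2 to compound 3 (0.22 log units; that floor lies within the scatter). Among these compounds, this is the first reading at this position; it sets only a floor for the step, and its true size stays unknown, with no sign of a lower number with hydrogen. The compounds shown leave open whether the same change behaves alike with the piperidin-1-yl group of compound 1, and how bromo or methoxy would read on this carbon.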